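The source may hold more compounds than are shown below. What is called first, only, known or untested is meant among the compounds shown, and "the series" means these compounds.

The compounds here share one core, and three of them have already been tested in a toxicity assay on HepG2 2.2.15 cells (Homo sapiens) for cytotoxicity, read by CCK-8 assay, with a stated time of 8 days; a lower number here means that less compound is tolerated, a higher number that more compound is tolerated. Compound 1 `CCOC(=O)c1cn(-c2nccs2)nc1CC(C)C` is the smallest of the set. In this assay compound 1 reaches only a limit, > 100000 nM. Compound 2 `CC(C)Cc1nn(-c2cccc(F)c2)cc1C(=O)NCC1CCN(C(=O)OC(C)(C)C)CC1` is a second member. In this assay compound 2 likewise reaches only a limit, > 100000 nM. Among the compounds with values here, compound 3 `CC(C)Cc1nn(-c2cccc(F)c2)cc1C(=O)NCc1ccccc1` is the one member with a real number: in this assay compound 3 gives 85900 nM. That leaves compound 3 standing alone with a measured value, framed by the limit of > 100000 nM in this assay, at which 2 of the 3 values shown sit. Compound 4 `CC(C)Cc1nn(-c2cccc(F)c2)cc1C(=O)NCc1ccc(F)cc1` is the compound still to be measured. It differs from compound 3 in one place: fluoro in place of hydrogen on an aromatic carbon. Within the data shown here, no pair of measured compounds shows the effect of a single change, so there is no measured step to lean on. Fluoro in place of hydrogen on an aromatic carbon is a small addition, and the expected step is modest, a 1.1-fold lower number from compound 3 to compound 4 (0.03 log units; within the scatter), not beyond the scatter in either direction. Compound 4 is therefore estimated at 80000 nM in this assay, with a likely range from 40000 nM to 160000 nM and a fair chance that only a limit is reported.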

Compound 4, half-maximal cytotoxic concentration: > 100000 nM
Compound 4 gave a limit, no number; the forecaster's own chance of this, stated with the estimate: 50%; middle value at least 1.2-fold (0.09 log units) from the limit.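

Within the data shown here, changing benzyl to 4-fluorobenzyl gives the first comparison in this set between two compounds that differ in one place, and in this assay it reads as an at least 1.1-fold higher number from compound 3 to compound 4 (0.06 log units; that floor lies within the scatter). So a fluoro on this aromatic carbon, para to a large group, gives no sign of lowering the number, yet the floor alone does not establish a real rise. How far the number moves cannot be read, because most of the set now sits at one limit: the limit of > 100000 nM in this assay, at which 3 of the 4 values shown sit.

The compounds shown leave open whether a different group at this place, such as chloro, methoxy or an amine, would give a real number instead of a limit. They also leave open what a carboxylic acid on this ring would do, or how fluoro would behave on another carbon of it.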